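The source may hold more compounds than are shown below. What is called first, only, known or untested is meant among the compounds shown, and "the series" means these compounds.

Measured compounds:
compound 1, `COc1ccc(/C=C\C(=O)O)c(OCc2cn(-c3ccccc3C(=O)N3CCC(O)C3)nn2)c1CC=C(C)C`, gives 13400 nM
compound 2, `COc1ccc(/C=C\C(=O)O)c(OCc2cn(-c3ccc(NC(C)=O)cc3)nn2)c1CC=C(C)C`, gives 17400 nM
compound 3, `COc1ccc(/C=C\C(=O)O)c(OCc2cn(-c3ccc(NC(=O)c4ccccc4)cc3)nn2)c1CC=C(C)C`, gives 23300 nM

These three compounds share one core and differ only in the group attached to an aromatic nitrogen of the triazole. All were tested in a functional assay on T47D cells (Homo sapiens) for cytotoxicity, read by MTT assay, with a stated time of 24 h; on this read-out higher numbers stand for weaker inhibition and lower numbers for stronger inhibition. Compound 2 stands second highest of the three numbers, between compound 1 and compound 3, and both of those gaps lie within the scatter of repeated measurements, so the three compounds cannot be placed in any order of strength on this read-out.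

Compound 4, `COc1ccc(/C=C\C(=O)O)c(OCc2cn(-c3nc4ccccc4s3)nn2)c1CC=C(C)C`, is not yet measured. It differs from compound 2 at the same aromatic nitrogen: 1,3-benzothiazol-2-yl in place of 4-acetamidophenyl on an aromatic nitrogen. Going by the values given here, the only measured step that touches this part of the molecule is a 1.3-fold higher number from compound 2 to compound 3 (0.13 log units; within the scatter), where the acetamide group was enlarged to a benzamide group without any shift beyond the scatter. Among the compounds with values here, no measured step replaces the whole ring at this position, so the change to compound 4 goes further than anything already tested. The step of a 1.2-fold lower number from compound 2 to compound 4 (0.06 log units; within the scatter) is therefore expected to be small, with no clear direction. For compound 4 the estimate in this assay is 15000 nM, within a range from 6000 nM to 40000 nM.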

Compound 4, half-maximal inhibitory concentration: 17200 nM
Compound 4: middle estimate off by 1.1-fold (0.06 log units), on the low side; measured number inside the range.
By their numbers in this assay, from the lowest: compounds 1, 4, 2 and 3 (each within the scatter of the next).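

Going by these compounds alone, until now the only change at this position was at the far end of the amide, whereas compound 4 replaces the entire 4-acetamidophenyl group with 1,3-benzothiazol-2-yl. Even so, this assay shows a 1.0-fold lower number from compound 2 to compound 4 (0.01 log units; within the scatter), a much larger structural change with no shift beyond the scatter, even though the amide is gone, the hydrogen-bond donor count falls to zero, and a five-membered aromatic ring with 2 hetero atoms and a sulfur atom come in. So, for these compounds on this read-out, neither the acetamide nor a lone carbon-only aromatic ring on the aromatic nitrogen is needed to keep the number where it stands, and no other measurement here offers an explanation for this flat result.

All the groups shown at this position carry an aromatic ring, so it remains open whether a plain butyl chain or a piperidine would also leave the number unchanged. As far as these compounds go, it is equally open whether a carboxylic acid or a primary amine on the phenyl ring of compound 2 would move the number beyond the scatter in either direction.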